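The source may hold more compounds than are shown below. What is called first, only, known or untested is meant among the compounds shown, and "the series" means these compounds.

Among the compounds with values here, in an assay on cells for inhibition of HSP60/HSP10 (Homo sapiens), with a stated time of 60 min (on this read-out higher numbers stand for weaker inhibition and lower numbers for stronger inhibition), compound 3 `O=S(=O)(Nc1ccc2oc(-c3ccccc3)nc2c1)c1ccc(O)cc1` gives 88000 nM, the only number among the three measured compounds. Compound 1 `O=S(=O)(Nc1ccc2oc(-c3ccccc3)nc2c1)c1ccc(Cl)cc1` returns only the limit > 100000 nM in this assay. Compound 2 `COc1ccc(Cl)cc1S(=O)(=O)Nc1ccc2oc(-c3ccccc3)nc2c1` likewise returns only the limit > 100000 nM. Two of the three values shown sit at the limit of > 100000 nM in this assay, at which 2 of the 3 values shown sit. The step of an at least 1.1-fold lower number from compound 1 to compound 3 (0.05 log units; that floor lies within the scatter) and the step of an at least 1.1-fold lower number from compound 2 to compound 3 (0.05 log units; that floor lies within the scatter) therefore have a floor that lies within the scatter, while the step that the two limits leave unreadable from compound 1 to compound 2 cannot be read at all. Compound 4 `O=S(=O)(Nc1ccc(-c2nc3cc(NS(=O)(=O)c4ccc(O)cc4)ccc3o2)cc1)c1ccc(O)cc1` differs from compound 3 in one place: ((4-hydroxyphenyl)sulfonyl)amino in place of hydrogen on an aromatic carbon. Within the data shown here, none of the measured steps alters the ring that carries the added group, so they carry little weight for this change; they show only that compound 3 is weakly active and that its neighbours reach no number. For compound 4 the estimate in this assay is 50000 nM, with a range from 10000 nM to 200000 nM. This estimate means a step of a 1.8-fold lower number from compound 3 to compound 4 (0.25 log units; within the scatter) that is expected to stay within the scatter.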

Compound 4, half-maximal inhibitory concentration: 14000 nM
Compound 4: middle estimate off by 3.6-fold (0.55 log units), on the high side, and the stated range covers the measured number.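

In this assay, ((4-hydroxyphenyl)sulfonyl)amino in place of hydrogen, on the aromatic carbon para to a large group, gives a 6.3-fold lower number from compound 3 to compound 4 (0.80 log units; beyond the scatter). This is the only readable step shown that lies beyond the scatter and the only change shown on this ring, and it shows that this position accepts a large group with a gain in inhibition, although compound 4 remains a weak inhibitor in absolute terms. Compound 1 and compound 2 stay at a limit of the assay, and the step between them cannot be read, nor can the exact size of their steps to compound 3: the limit of > 100000 nM in this assay, at which 2 of the 4 values shown sit.

On these data alone, it remains open whether the whole added group is needed for the gain, or whether a smaller group at this position, such as a plain amine or a carboxylic acid, would give a similar number. It is also open whether the hydroxy on the added ring matters, as no compound shown carries a methoxy or a chloro there.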